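Adding Fluoro to the Phenyl Group of Compound 2

The compounds below may be only part of what the source reports. "The series", "measured", "known", "first", "only" and "open" are said of these compounds alone.

Among the compounds with values here, compound 2 `O=C(c1ccccc1)N1CCCn2nc(COc3ccccc3)cc21` gives 63% in a functional assay on HEK293 cells for positive allosteric modulation of metabotropic glutamate receptor 5 (Homo sapiens), read by calcium flux (on this read-out lower numbers stand for smaller maximal responses and higher numbers for larger maximal responses), the higher of the two values measured so far; compound 1 `CCC(=O)N1CCCn2nc(COc3ccccc3)cc21` gives 48%. Within the data shown here, the only measured step, a number 15 percentage points higher from compound 1 to compound 2 (beyond the scatter), exchanged the whole group on the carbonyl carbon rather than changing a single atom on the phenyl. Compound 3 `O=C(c1ccc(F)cc1)N1CCCn2nc(COc3ccccc3)cc21` differs from compound 2 by fluoro in place of hydrogen on an aromatic carbon. Among the measured compounds shown here, no measured step touches the phenyl itself, so the size and direction of this change are open. Compound 3 is expected to reach about 63%, within 45% to 80%, an estimated step of no change at the digits printed from compound 2 to compound 3 (within the scatter) that likely stays within the scatter.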

Compound 3, largest response reached (reported as percent of maximum), in percent of the reference or control that the assay uses: 63%
Beside the measured number, compound 3's estimate shows no gap at the digits printed; low and high end bracket the measured number.
By their numbers in this assay, from the lowest: compound 1; then compounds 2 and 3 (each within the scatter of the next).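

In this assay, fluoro in place of hydrogen at this spot on the phenyl, para to a large group, gives no change at the digits printed from compound 2 to compound 3 (within the scatter), so this single-atom change leaves the maximal response where it was. The gain over ethyl on the carbonyl carbon also holds with the fluorinated ring, with a number 15 percentage points higher from compound 1 to compound 3 (beyond the scatter). Nothing measured here offers an explanation for this result. From the compounds shown here alone, whether a methoxy group, a trifluoromethyl group or an amine at the same spot would move the response remains open. So does the effect of fluoro on the other carbons of this ring.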